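Amine Substituent Swap in an Antiproliferative Series

A few compounds are considered here, and "the series" means these few. Any claim that something is new, unique, unknown or untested is made for them only; others in the source may bear on it.

Compound 1, `CC(C)=CCc1cc(C(=O)Nc2cc3ccc(OCC4CCN(C)C4)c(C)c3oc2=O)ccc1O`: in a functional assay on SK-BR-3 cells (Homo sapiens) for antiproliferative activity (on this read-out higher numbers stand for weaker inhibition and lower numbers for stronger inhibition), compound 1 gives 920 nM.
Compound 2, `CCCNCCCOc1ccc2cc(NC(=O)c3ccc(O)c(CC=C(C)C)c3)c(=O)oc2c1C`: in this assay compound 2 gives 990 nM.

Of the two numbers, that of compound 2 is the higher, yet the step of a 1.1-fold higher number from compound 1 to compound 2 (0.03 log units; within the scatter) lies within the scatter, so the two compounds are not separated. Compound 3, `CC(C)=CCc1cc(C(=O)Nc2cc3ccc(OCCCNC(C)(C)C)c(C)c3oc2=O)ccc1O`, differs from compound 2 by tert-butyl in place of propyl on an amine nitrogen. Going by the values given here, no measured step touches this amine substituent; the only step known altered the same side chain without effect beyond the scatter. Compound 3 is therefore expected to show a step of a 1.0-fold higher number from compound 2 to compound 3 (0.00 log units; within the scatter), within the scatter. Compound 3 is estimated at 1000 nM, between 400 nM and 2500 nM.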

Compound 3, half-maximal inhibitory concentration: 660 nM
For compound 3 the middle estimate is 1.5-fold (0.18 log units) above the measured one; low and high end bracket the measured number.
By their numbers in this assay, from the lowest: compounds 3, 1 and 2 (each within the scatter of the next).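

In this assay, tert-butyl in place of propyl on the amine nitrogen gives a 1.5-fold lower number from compound 2 to compound 3 (0.18 log units; within the scatter), and 2-((tert-butyl)amino)ethyl in place of 1-methylpyrrolidin-3-yl gives a 1.4-fold lower number from compound 1 to compound 3 (0.14 log units; within the scatter). Neither step separates the compounds, so a change of the substituent on the amine nitrogen itself, like the earlier change of the side chain, has no effect here beyond the scatter. No evidence bears on this result. On these data alone, whether a carboxylic acid or a longer chain in place of this amine would shift the number beyond the scatter remains open.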